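The compounds below may be only part of what the source reports. "The series", "measured", "known", "first", "only" and "open" are said of these compounds alone.

Measured compounds:
compound 1 `COc1cccc(OC)c1[C@@H]1C[C@H](N(C)C)C(=O)N1Cc1ccc(OC(F)(F)F)cc1`, 8300 nM
compound 2 `COc1cccc(OC)c1[C@@H]1C[C@@H](Cl)C(=O)N1Cc1ccc(OC(F)(F)F)cc1`, 563 nM

In a functional assay on CHO cells for antagonist activity at Orexin receptor type 2 (Homo sapiens), read by FLIPR and calcium flux (on this read-out lower numbers stand for stronger inhibition and higher numbers for weaker inhibition), compound 1 gives 8300 nM, the highest of the two numbers; compound 2 gives 563 nM, a lower number beyond the scatter. Among the measured compounds shown here, no step between measured compounds is given for the change in hand.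

Compound 3 `CN[C@H]1C[C@@H](c2c(OC)cccc2OC)N(Cc2ccc(OC(F)(F)F)cc2)C1=O` differs from compound 1 by hydrogen in place of methyl on an amine nitrogen, the same difference cut one bond further out reading dimethylamino to methylamino. With no comparable step shown, a small change is expected, a 1.4-fold lower number from compound 1 to compound 3 (0.14 log units; within the scatter), not clearly beyond the scatter in either direction. Compound 3 is estimated at 6000 nM, range 2000 nM to 20000 nM in this assay.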

Compound 3, half-maximal inhibitory concentration: > 10000 nM
Compound 3 gave a limit, no number; the forecaster's own chance of this, stated with the estimate: 10%; middle value at least 1.6-fold (0.22 log units) from the limit.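

In this assay, from the compounds shown here alone, hydrogen in place of methyl on an amine nitrogen gives an at least 1.2-fold higher number from compound 1 to compound 3 (0.08 log units; that floor lies within the scatter), a floor and not a measured step, so its true size stays unknown. Compound 3 gives a limit and not a number: the limit of > 10000 nM in this assay, at which 1 of the 3 values shown sits.

Going from dimethylamino to methylamino at this place therefore gives no sign of a lower number, which the earlier compounds could not show. Still open, going by these compounds, is how a primary amine, a hydroxyl or an acetamide at this place would read in this assay.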